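The source may report more compounds than this note shows. Statements on the series, on what has been measured and on what is new or still open speak of the compounds shown alone.

Measured in a physicochemical assay for solubility, measured as kinetic solubility, at pH 2; on this read-out lower numbers stand for lower solubility and higher numbers for higher solubility:
- compound 1 `CC(C)[C@@H](c1ccc(-c2ccc3cccc(F)c3c2)[nH]c1=O)[C@@H]1OC(=O)NC1=O`: 6900 nM
- compound 2 `CC(C)C(c1ccc(-c2ccc3cccc(F)c3c2)[nH]c1=O)C1NC(=O)NC1=O`: 5800 nM
- compound 3 `CC(C)[C@H](C[C@H]1OC(=O)NC1=O)c1ccc(-c2ccc3cccc(F)c3c2)[nH]c1=O`: 24400 nM

Compound 3 has the highest number of the three, clear of both compound 1 and compound 2 by more than the scatter.

The next structure is compound 4 `CC(C)[C@@H](c1ccc(-c2ccc3cccc(F)c3c2)[nH]c1=O)[C@H]1OC(=O)NC1=O`, with 2,4-dioxo-1,3-oxazolidin-5-yl in place of (2,4-dioxo-1,3-oxazolidin-5-yl)methyl on a saturated chain carbon bound to an aromatic carbon and a saturated chain carbon.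

Among the compounds with values here, one measured step bears on this exchange: a 3.5-fold higher number from compound 1 to compound 3 (0.55 log units; beyond the scatter). It is modest but beyond the scatter, and the change now runs the opposite way. A modest step of similar size to a lower number is therefore expected in this assay, namely a 3.6-fold lower number from compound 3 to compound 4 (0.55 log units; beyond the scatter). Within the data shown here, this rests on a single pair, and no measured step isolates the defined stereocentre, so the range is kept wide.

The estimated value for compound 4 is 6800 nM, with an expected range of 3000 nM to 14000 nM.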

Compound 4, solubility: 5400 nM
Beside the measured number, compound 4's estimate is 1.3-fold (0.10 log units) above it; measured number inside the range.
By their numbers in this assay, from the lowest: compounds 4, 2 and 1 (each within the scatter of the next); then compound 3.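

In this assay, the configuration at the saturated ring carbon gives no readable change, with a 1.3-fold lower number from compound 1 to compound 4 (0.11 log units; within the scatter), and this pair isolates that stereocentre: the fact that compounds 1 and 4 differ only in the configuration as drawn. The drop on removing the extra carbon, a 4.5-fold lower number from compound 3 to compound 4 (0.65 log units; beyond the scatter), is beyond the scatter, so the gap to compound 3 is now seen with both drawn configurations of the 2,4-dioxo-1,3-oxazolidin-5-yl group on the saturated chain carbon. Among these compounds, the higher number therefore goes with (2,4-dioxo-1,3-oxazolidin-5-yl)methyl and not with one ring configuration.

From the compounds shown here alone, whether compound 3's number depends on the configurations drawn in that compound remains open. It is also unknown whether a longer chain carrying the same ring would raise the number further, or how a carboxylic acid at this place would compare in this assay.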